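Chloro for methyl on the phenyl ring of compound 2

The compounds below may be only part of what the source reports. "The series", "measured", "known", "first", "only" and "open" are said of these compounds alone.

Two members of the series have been measured so far. Compound 1 `COc1cccc(/C=C/C(=O)NNC(=O)c2ccc3c(c2)OCCO3)c1` gives 398000 nM in an ADME assay on cells (Macrophage) for cytotoxicity, read by MTT assay, with a stated time of 24 h; on this read-out lower numbers stand for higher toxicity in this test and higher numbers for lower toxicity in this test. Compound 2 `Cc1ccccc1/C=C/C(=O)NNC(=O)c1ccc2c(c1)OCCO2` gives 268000 nM in this assay. The one step between them, a 1.5-fold lower number from compound 1 to compound 2 (0.17 log units; within the scatter), stays within the scatter, so on the numbers shown compound 2 holds the lowest of the two values, with compound 1 as its nearest neighbour and no separation that can be read as a real difference.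

Compound 3 `O=C(/C=C/c1ccccc1Cl)NNC(=O)c1ccc2c(c1)OCCO2` is not yet measured. It differs from compound 2 by chloro in place of methyl on an aromatic carbon. Going by the values given here, no measured step involves a chloro group; the only step available changed the phenyl substituents and remained within the scatter. Among the compounds with values here, that step is the sole guide, and it gives no reason to expect movement beyond the scatter in this assay in either direction. The expected step is a 1.0-fold higher number from compound 2 to compound 3 (0.02 log units; within the scatter), which amounts to no change beyond the scatter. Compound 3 is thus estimated at 280000 nM, with a range from 120000 nM to 650000 nM.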

Compound 3, half-maximal cytotoxic concentration: 285000 nM
Beside the measured number, compound 3's estimate is 1.0-fold (0.01 log units) below it; the measured number falls inside the stated range.
By their numbers in this assay, from the lowest: compounds 2, 3 and 1 (each within the scatter of the next).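

In this assay, chloro in place of methyl on an aromatic carbon, ortho to a large group, brings no step beyond the scatter (a 1.1-fold higher number from compound 2 to compound 3 (0.03 log units; within the scatter)). Going by these compounds alone, this is the first reading of a halogen on the phenyl ring, and at this position the exchange of a carbon for a chlorine leaves compound 2 and compound 3 inseparable in this test. Set against the 3-methoxyphenyl group of compound 1, the 2-chlorophenyl group also stays within the scatter (a 1.4-fold lower number from compound 1 to compound 3 (0.15 log units; within the scatter)), so the three phenyl variants form a single group with no order among them, and no measured evidence bears on the reason for this.

From the compounds shown here alone, all three compounds carry a single small uncharged substituent on the phenyl ring, so it remains open whether an amine, a carboxylic acid or a longer chain there would give a step beyond the scatter. Going by these compounds, the effect of any change to the shared core in this test also remains open, as all three compounds keep that core unchanged.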